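Methylpyridyl Swap on a Shared Core: Exposure Outlook

The compounds below may be only part of what the source reports. "The series", "measured", "known", "first", "only" and "open" are said of these compounds alone.

Three compounds with a shared core were examined in an ADME assay on the whole organism for pharmacokinetics, with Rattus norvegicus as the target, with a stated time of 6 h, at a dose of 10 mg/kg by the oral route; on this read-out lower numbers stand for lower exposure and higher numbers for higher exposure at the dose given:
compound 1 `Cc1cn2c(-c3cn[nH]c3)cnc2c(Nc2cc(Cn3cccc(C)c3=O)ns2)n1` — "not determined" (no result reported);
compound 2 `Cc1cn2c(-c3cn[nH]c3)cnc2c(Nc2cc(Cc3cnccn3)ns2)n1` — 58.4 ng.h/mL;
compound 3 `Cc1cn2c(-c3cn[nH]c3)cnc2c(Nc2cc(Cc3cccnc3)ns2)n1` — "not determined" (no result reported).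

Compound 3 therefore stands without a single number in this assay, and compound 1 is the other entry without one; only compound 2 offers a measured exposure. Compound 4 `Cc1cccc(Cc2cc(Nc3nc(C)cn4c(-c5cn[nH]c5)cnc34)sn2)n1` differs from compound 3 by 6-methylpyridin-2-yl in place of pyridin-3-yl on a saturated chain carbon bound to an aromatic carbon. Within the data shown here, with no step between measured compounds to go by, the size of the move from compound 3 to compound 4 in this assay cannot be read from the data, and nothing beyond the usual scatter is assumed in either direction. Resting on the value of compound 2, 58.4 ng.h/mL, compound 4 is expected to give about 60 ng.h/mL, in a range from 15 ng.h/mL to 250 ng.h/mL.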

Compound 4, area under the concentration-time curve: 3100 ng.h/mL
For compound 4 the middle estimate is 52-fold (1.71 log units) below the measured one, and the stated range ends below it.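

In this assay, the group on the saturated chain carbon bound to an aromatic carbon clearly matters: 6-methylpyridin-2-yl in place of pyrazin-2-yl gives a 53-fold higher number from compound 2 to compound 4 (1.72 log units; beyond the scatter) on the shared core. Among these compounds, this is the first measured step at this position, and it shows that a change confined to this one group can shift exposure far beyond the scatter. Nothing measured here explains the rise.

On these data alone, with no single number for compound 3, its step to compound 4 cannot be read, and the methyl group's share of the rise stays unknown. As far as these compounds go, how a methoxy group or a trifluoromethyl group in place of that methyl would behave also remains open.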